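The source may report more compounds than this note shows. Statements on the series, on what has been measured and on what is new or still open speak of the compounds shown alone.

Three compounds share one core and differ only in the group on an aromatic carbon of a six-membered aromatic ring of carbon only. Compound 1 `CCN(CC)c1ccc(NC(=O)c2cn(Cc3c(F)cccc3F)c3ccc(=O)[nH]c3c2=O)cc1` carries a diethylamino group there, and in an in vitro assay on Sf21 cells for inhibition of high affinity 3',5'-cyclic-AMP phosphodiesterase 7A (Homo sapiens), read by scintillation proximity assay, with a stated time of 30 min (on this read-out higher numbers stand for weaker inhibition and lower numbers for stronger inhibition), compound 1 gives 46 nM. Compound 2 `N#Cc1ccc(NC(=O)c2cn(Cc3c(F)cccc3F)c3ccc(=O)[nH]c3c2=O)cc1` carries a cyano group instead, and in this assay compound 2 gives 96 nM. Compound 3 `O=C(NCc1ccncc1)c1ccc(NC(=O)c2cn(Cc3c(F)cccc3F)c3ccc(=O)[nH]c3c2=O)cc1` carries a ((pyridin-4-yl)methyl)carbamoyl group, and in this assay compound 3 gives 20 nM, the lowest of the three numbers. The measured steps are a 2.1-fold higher number from compound 1 to compound 2 (0.32 log units; beyond the scatter), a 2.3-fold lower number from compound 1 to compound 3 (0.36 log units; beyond the scatter) and a 4.8-fold lower number from compound 2 to compound 3 (0.68 log units; beyond the scatter).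

Compound 4 `O=C(Nc1ccc(S(=O)(=O)Nc2nccs2)cc1)c1cn(Cc2c(F)cccc2F)c2ccc(=O)[nH]c2c1=O` takes the next step: (1,3-thiazol-2-yl)sulfamoyl in place of ((pyridin-4-yl)methyl)carbamoyl on an aromatic carbon. The group that leaves and the group that enters are of similar size, each with an aromatic ring and one hydrogen-bond donor. Within the data shown here, the steps that bear on this change are a 2.3-fold lower number from compound 1 to compound 3 (0.36 log units; beyond the scatter) and a 4.8-fold lower number from compound 2 to compound 3 (0.68 log units; beyond the scatter), which show that compound 3, with the larger group, sits below both compounds 1 and 2. Among the measured compounds shown here, no measured step swaps one large group for another, so the direction of this change is uncertain. Compound 4 is therefore expected to stay near compound 3, with an estimated step of a 1.5-fold higher number from compound 3 to compound 4 (0.18 log units; within the scatter). The estimate for compound 4 in this assay is 30 nM, expected to fall between 10 nM and 90 nM.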

Compound 4, half-maximal inhibitory concentration: 25 nM
Compound 4: the middle estimate sits 1.2-fold (0.08 log units) above what was measured, within the range that was stated.
By their numbers in this assay, from the lowest: compounds 3, 4 and 1 (each within the scatter of the next, the first and the last beyond it); then compound 2.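

In this assay, among these compounds, the step of a 1.3-fold higher number from compound 3 to compound 4 (0.10 log units; within the scatter) is the first swap of one large group for another at this position, and it stays within the usual scatter, even though a sulfamoyl link replaces a carbamoyl link and a five-membered aromatic ring replaces a six-membered one. The step of a 3.8-fold lower number from compound 2 to compound 4 (0.58 log units; beyond the scatter) lies beyond the scatter, so compound 4, like compound 3, stands apart from the cyano compound. The step of a 1.8-fold lower number from compound 1 to compound 4 (0.26 log units; within the scatter) lies within the scatter, whereas the step of a 2.3-fold lower number from compound 1 to compound 3 (0.36 log units; beyond the scatter) lies beyond it, so the diethylamino compound is clearly separated from compound 3 but not from compound 4.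

Nothing measured here explains why these groups give the numbers they do. On these data alone, it remains open whether the link or the ring at its end matters more in the two large groups, and what a carboxylic acid, a primary amine or a longer chain between the link and the ring would give at this position.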